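Replacing an Acetyl Group on Two Related Cores

The source may hold more compounds than are shown below. What is called first, only, known or untested is meant among the compounds shown, and "the series" means these compounds.

Compound 2 `C=C1[C@H](OC(C)=O)[C@@H](OC(C)=O)[C@@H](OC(C)=O)C(C)(C)/C=C/[C@H](C)[C@H](OC(=O)c2ccccc2)[C@@]2(O)C[C@@](C)(OC(C)=O)[C@H](OC(C)=O)[C@@H]2[C@H]1OCC(C)C` carries acetyl groups on its core, and compound 1 `C=C1[C@H](OC(C)=O)[C@@H](OC(=O)c2cccc(C)c2)[C@@H](OC(C)=O)C(C)(C)/C=C/[C@H](C)[C@H](OC(=O)c2ccccc2)[C@@]2(O)C[C@@](C)(OC(C)=O)[C@H](OC(C)=O)[C@@H]2[C@H]1OCC(C)C` differs from it only by 3-methylphenyl in place of methyl on a carbonyl carbon. In a functional assay on NCI/ADR-RES cells (Homo sapiens) for antiproliferative activity, read by MTT assay, with a stated time of 48 h (on this read-out lower numbers stand for stronger inhibition and higher numbers for weaker inhibition), compound 2 gives > 100000 nM, which is a limit of the assay. In this assay compound 1 gives > 100000 nM, also a limit. The step that the two limits leave unreadable from compound 2 to compound 1 therefore cannot be read; both values sit at the limit of > 100000 nM in this assay, at which 3 of the 3 values shown sit. Compound 3 `C=C1[C@H](OC(C)=O)[C@@H](OC(C)=O)[C@@H](OC(C)=O)C(C)(C)/C=C/[C@H](C)[C@H]2O[C@]3(C)C[C@@]2(OC(=O)c2ccccc2)[C@H]([C@H]3OC(C)=O)[C@H]1OCC(C)C` is built on a different core, and how its core differs from that of compound 2 is not broken down here. In this assay compound 3 gives > 100000 nM, again a limit. Compound 4 `C=C1[C@H](OC(C)=O)[C@@H](OC(=O)c2cccc(C)c2)[C@@H](OC(C)=O)C(C)(C)/C=C/[C@H](C)[C@H]2O[C@]3(C)C[C@@]2(OC(=O)c2ccccc2)[C@H]([C@H]3OC(C)=O)[C@H]1OCC(C)C` arises from compound 3 by the same change, (3-methylphenyl in place of methyl on a carbonyl carbon), at the same place. Compound 3 sits at the limit of > 100000 nM in this assay, at which 3 of the 3 values shown sit, and the earlier step that the two limits leave unreadable from compound 2 to compound 1 gave no readable size. The step of a number no higher from compound 3 to compound 4 (the limit leaves the size open) is therefore expected to be close to nil. Compound 4 is expected to give 100000 nM in this assay, most likely again only as a limit.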

Compound 4, half-maximal inhibitory concentration: > 100000 nM
Compound 4 gave a limit, no number; the forecaster's own chance of this, stated with the estimate: 85%; the middle value sits exactly at the limit.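

Compound 3 and compound 4 both sit at a limit, so no step between them can be read: the limit of > 100000 nM in this assay, at which 4 of the 4 values shown sit.

The compounds shown leave open whether 3-methylphenyl in place of methyl changes activity on either core in this assay at all.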